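Amide series: pyrazinyl replacing pyrazolyl at the aryl amide

A few compounds are considered here, and "the series" means these few. Any claim that something is new, unique, unknown or untested is made for them only; others in the source may bear on it.

Two compounds of the series have numbers in a functional assay for antagonist activity at transient receptor potential cation channel subfamily V member 1 (Homo sapiens), read by FLIPR and calcium flux; a higher number here means a more potent compound, by a factor of ten per unit of this negative logarithm, a lower number a less potent compound. Compound 1 `CC(=O)c1cccc(-c2ccc(C(=O)Nc3ccc4c(c3)N(C)CCC4)cc2)c1` gives 7 in this assay. Compound 2 `CN1CCCc2ccc(NC(=O)c3ccc(-n4cccn4)cc3)cc21` gives 6.9 in this assay. The only measured step, a number 0.10 log units lower from compound 1 to compound 2 (within the scatter), shows that these two values do not separate, so compound 2 cannot be set apart from compound 1 on the numbers shown.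

Compound 3 `CN1CCCc2ccc(NC(=O)c3ccc(-c4cnccn4)cc3)cc21` differs from compound 2 by pyrazin-2-yl in place of 1H-pyrazol-1-yl on an aromatic carbon, the entering group sitting para to a large group. No measured step covers a pyrazinyl group; the one step shown, from compound 1 to compound 2, exchanged the group at this same position for an unrelated one without a change beyond the scatter. On that basis no change beyond the scatter is expected in this assay either. Compound 3 is therefore estimated at 6.9, with a range from 6.3 to 7.5. This corresponds to an expected step of no change at the digits printed from compound 2 to compound 3 (within the scatter).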

Compound 3, negative logarithm of the antagonist equilibrium constant: 7.1
Compound 3: middle estimate off by 0.20 log units, on the low side; low and high end bracket the measured number.
By their numbers in this assay, from the lowest: compounds 2, 1 and 3 (each within the scatter of the next).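

In this assay, pyrazin-2-yl in place of 1H-pyrazol-1-yl gives a small step (a number 0.20 log units higher from compound 2 to compound 3 (within the scatter)), and pyrazin-2-yl in place of 3-acetylphenyl gives another (a number 0.10 log units higher from compound 1 to compound 3 (within the scatter)). This position, on an aromatic carbon of a six-membered aromatic ring of carbon only and para to a large group, now carries a six-membered aromatic ring with 2 hetero atoms as well as the five-membered one and 3-acetylphenyl, and the values of the three compounds do not separate. Nothing on hand offers a reason for this result.

From the compounds shown here alone, all three groups at this position are aromatic rings, so the outcome with a carboxylic acid, an amine or a longer chain there remains open. Changes to the shared core also remain open, since it is the same in all three compounds.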